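Dichlorophenyl imine of a pyrazolone: an estimate

A few compounds are considered here, and "the series" means these few. Any claim that something is new, unique, unknown or untested is made for them only; others in the source may bear on it.

Three imines built on one shared core have been measured in a functional assay on HT-29 cells (Homo sapiens) for cytotoxicity, read by MTT assay, with a stated time of 72 h; a higher number here means a weaker inhibitor, a lower number a stronger inhibitor. Compound 1 `COc1ccc(/C=N/c2c(C)n(C)n(-c3ccccc3)c2=O)cc1` gives 589000000 nM in this assay. Compound 2 `COc1cccc(/C=N/c2c(C)n(C)n(-c3ccccc3)c2=O)c1` gives 155000000 nM, and compound 3 `COc1ccccc1/C=N/c1c(C)n(C)n(-c2ccccc2)c1=O` gives 70800000 nM. For the measured compounds named here, the only changes among them are in where the methoxy sits on the aryl ring: a 3.8-fold lower number from compound 1 to compound 2 (0.58 log units; beyond the scatter), an 8.3-fold lower number from compound 1 to compound 3 (0.92 log units; beyond the scatter), and a 2.2-fold lower number from compound 2 to compound 3 (0.34 log units; beyond the scatter). Compound 3 therefore stands lowest of the three, beyond the scatter from both compound 2 and compound 1.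

Compound 4 `Cc1c(/N=C/c2ccc(Cl)cc2Cl)c(=O)n(-c2ccccc2)n1C` differs from compound 3 in one place: 2,4-dichlorophenyl in place of 2-methoxyphenyl on a carbon with a double bond to nitrogen. Going by the values given here, none of the measured steps bears directly on this change; all three concern a methoxy moved about the ring, none swaps methoxy for chlorine or adds a second substituent. Among the compounds with values here, with no step of that kind in hand, the change is taken to fall within the range those three steps span, and no step beyond the scatter is expected in this assay, in either direction, though the spread is wide. Compound 4 is thus estimated at 50000000 nM, with a range from 12000000 nM to 250000000 nM, which means an expected step of a 1.4-fold lower number from compound 3 to compound 4 (0.15 log units; within the scatter).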

Compound 4, half-maximal inhibitory concentration: 178000000 nM
Compound 4: middle estimate off by 3.6-fold (0.55 log units), on the low side; measured number inside the range.
By their numbers in this assay, from the lowest: compound 3; then compounds 2 and 4 (each within the scatter of the next); then compound 1.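

In this assay, for the compounds shown here, the earlier steps only moved a methoxy around the aryl ring, whereas this one replaces 2-methoxyphenyl with 2,4-dichlorophenyl on the carbon with a double bond to nitrogen, and the result is a 2.5-fold higher number from compound 3 to compound 4 (0.40 log units; beyond the scatter). So this position tolerates a group without oxygen and with two chlorines, but the change does not take the number below that of compound 3, which remains the lowest of the four; the comparison with the other two methoxy compounds places the new group inside their span, with a 3.3-fold lower number from compound 1 to compound 4 (0.52 log units; beyond the scatter) and with a 1.1-fold higher number from compound 2 to compound 4 (0.06 log units; within the scatter). The change also removes the hydrogen-bond acceptor counted in the 2-methoxyphenyl group, but no available data connect that difference, or any other, to these steps.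

The compounds shown leave open how much each chlorine of compound 4 contributes on its own, and whether an amine or a carboxylic acid on this aryl ring would give a number outside the span seen so far. They also leave open what a longer chain in place of the methoxy would do at this position.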